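Swapping nitro for sulfamoyl on a very weak binder

The compounds below may be only part of what the source reports. "The series", "measured", "known", "first", "only" and "open" are said of these compounds alone.

Compound 1 `CCCCCCCCc1ccc(C(=O)Nc2ccccc2B(O)O)cc1` and compound 2 `CCCCCCCCc1ccc(C(=O)Nc2ccccc2[N+](=O)[O-])cc1` share one core and differ in a single group. In an assay for binding affinity to serine/threonine-protein kinase PLK1 (Homo sapiens), read by fluorescence polarization, with a stated time of 45 min (a higher number here means a weaker inhibitor, a lower number a stronger inhibitor), compound 1 gives only a limit of the assay, > 600000 nM. In this assay compound 2 likewise gives only a limit, > 600000 nM. The step that the two limits leave unreadable from compound 1 to compound 2 is therefore not readable, as the limit of > 600000 nM in this assay, at which 2 of the 2 values shown sit, shows. Compound 3 `CCCCCCCCc1ccc(C(=O)Nc2ccccc2S(N)(=O)=O)cc1` carries sulfamoyl in place of nitro on an aromatic carbon. With no readable measured step to draw on, the step of a number no higher from compound 2 to compound 3 (the limit leaves the size open) is expected to be none beyond the scatter. For compound 3 the estimate in this assay is 600000 nM, with a range from 100000 nM to 3000000 nM.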

Compound 3, half-maximal inhibitory concentration: 259000 nM
Compound 3: middle estimate off by 2.3-fold (0.36 log units), on the high side; the range from low to high includes it.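

In this assay, for the compounds shown here, sulfamoyl on an aromatic carbon, ortho to a large group, gives the first readable number at this position, with an at least 2.3-fold lower number from compound 2 to compound 3 (0.36 log units; beyond the scatter) and an at least 2.3-fold lower number from compound 1 to compound 3 (0.36 log units; beyond the scatter). Each step gives only its smallest possible size, and the true size stays unknown, because the other end of each is a limit: the limit of > 600000 nM in this assay, at which 2 of the 3 values shown sit.

The compounds shown leave open whether an amine or a carboxylic acid at this position would lower the number further. They also leave open what a longer chain elsewhere on the shared core would do alongside sulfamoyl.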